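This account rests on a few compounds, and the source may have more. Where it says the series, first, only, none or still open, it means among the compounds named here.

Working notes on the series. The common scaffold is shown by compound 1 `O=C1/C(=C\c2ccccc2)N=C(c2ccccc2)N1c1ccc2oc(-c3ccccc3)cc(=O)c2c1`, which in a functional assay on MDA-MB-435 cells (Homo sapiens) for inhibition, read by MTT assay (on this read-out lower numbers stand for stronger inhibition and higher numbers for weaker inhibition), gives 24.3 ug/mL. Compound 2 `O=C1/C(=C\c2ccc(Cl)c(Cl)c2)N=C(c2ccccc2)N1c1ccc2oc(-c3ccccc3)cc(=O)c2c1` gives 16.9 ug/mL in this assay, and compound 3 `COc1ccc(/C=C2/N=C(c3ccccc3)N(c3ccc4oc(-c5ccccc5)cc(=O)c4c3)C2=O)cc1OC` gives 10.8 ug/mL. Compound 3 holds the lowest number of the three; against compound 2 the gap is within the scatter, against compound 1 it is beyond it, so compound 3 is only separated from compound 1 with any confidence. The measured steps all sit on the same aryl group: a 1.4-fold lower number from compound 1 to compound 2 (0.16 log units; within the scatter), a 2.3-fold lower number from compound 1 to compound 3 (0.35 log units; beyond the scatter) and a 1.6-fold lower number from compound 2 to compound 3 (0.19 log units; within the scatter). Within the data shown here, only the step from compound 1 to compound 3 passes the scatter, and it is modest.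

Compound 4 `O=C1/C(=C\c2ccc(O)cc2)N=C(c2ccccc2)N1c1ccc2oc(-c3ccccc3)cc(=O)c2c1` is the next member, not yet measured. Its change from compound 3 is 4-hydroxyphenyl in place of 3,4-dimethoxyphenyl on a double-bonded chain carbon bound to a double-bonded ring carbon. The three measured steps bear on it, since they alter the same aryl group, and they show that swapping substituents there moves this assay by at most a modest amount. A step of similar size, in either direction or none beyond the scatter, is therefore expected; the estimated step is a 1.3-fold higher number from compound 3 to compound 4 (0.11 log units; within the scatter). Compound 4 is expected to give about 14 ug/mL in this assay, within a range from 6 ug/mL to 32 ug/mL.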

Compound 4, half-maximal inhibitory concentration: 18 ug/mL
For compound 4 the middle estimate is 1.3-fold (0.11 log units) below the measured one; the range from low to high includes it.
By their numbers in this assay, from the lowest: compounds 3, 2, 4 and 1 (each within the scatter of the next, the first and the last beyond it).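

In this assay all three new steps stay within the scatter: a 1.7-fold higher number from compound 3 to compound 4 (0.22 log units; within the scatter), a 1.1-fold higher number from compound 2 to compound 4 (0.03 log units; within the scatter) and a 1.4-fold lower number from compound 1 to compound 4 (0.13 log units; within the scatter). Among these compounds, with 4-hydroxyphenyl, a hydrogen-bond donor enters this aryl group for the first time, yet hydroxy in place of hydrogen on an aromatic carbon does not separate compound 4 from compound 1, and compound 4 also cannot be told apart from compound 2 or compound 3, even though 4-hydroxyphenyl has fewer heavy atoms than 3,4-dimethoxyphenyl. No measurement is available that would account for these small steps.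

The compounds shown leave open whether an amine, a carboxylic acid or a longer chain on this aryl group would move the number beyond the scatter, or whether this position simply tolerates a wide range of substituents in this assay. From the compounds shown here alone, every change so far sits on the same aryl group, so how the rest of the shared core contributes to the read-out also remains open.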